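The source may hold more compounds than are shown below. What is called first, only, known or untested is meant among the compounds shown, and "the series" means these compounds.

Measured so far:
compound 1, `CCn1c(/C=C2\SC(=O)N(CC(=O)N3CCOCC3)C2=O)nc2ccccc21`, gives > 50000 nM
compound 2, `Cn1c(/C=C2\SC(=O)N(CC(=O)N3CCCC3)C2=O)nc2ccccc21`, gives > 50000 nM

Both values come from a functional assay on PC-3 cells (Homo sapiens) for inhibition, read by MTT assay, with a stated time of 48 h; a higher number here means a weaker inhibitor, a lower number a stronger inhibitor. For compound 1 the figure > 50000 nM is a limit of the assay and not a number. For compound 2 the figure > 50000 nM is likewise a limit of the assay and not a number. Compound 2 therefore stands at the limit at which both measured values sit (the limit of > 50000 nM in this assay, at which 2 of the 2 values shown sit), and no order between the two compounds can be read from these figures.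

Compound 3, `CCn1c(/C=C2\SC(=O)N(CC(=O)N3CCCC3)C2=O)nc2ccccc21`, has not yet been measured. It differs from compound 2 in one place: methyl in place of hydrogen on a saturated chain carbon bound to an aromatic nitrogen. Among the compounds with values here, no step between measured compounds is known here, so there is no measured pair to set the size of this change. Because both measured values sit at the limit (the limit of > 50000 nM in this assay, at which 2 of the 2 values shown sit), the step that the limit leaves unreadable from compound 2 to compound 3 is expected to be none beyond the usual scatter. Compound 3 is accordingly estimated at 80000 nM, with a range from 30000 nM to 300000 nM, and most likely reported again only as a limit.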

Compound 3, half-maximal inhibitory concentration: > 50000 nM
Compound 3 gave a limit, no number (the forecaster's own chance of this, stated with the estimate: 85%); the middle value is on the limit's open side.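

In this assay compound 3 gives > 50000 nM, which is a limit and not a number. No step from compound 1 or compound 2 to compound 3 can be read, because all three compounds sit at the same limit: the limit of > 50000 nM in this assay, at which 3 of the 3 values shown sit 

The compounds shown leave open how strongly any of them inhibits, and whether either structural change affects that strength at all.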